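The source may report more compounds than this note shows. Statements on the series, on what has been measured and on what is new or still open speak of the compounds shown alone.

Measured in an assay on CHO cells for displacement of a labelled ligand from Glucagon receptor (Homo sapiens), read by scintillation counting, with a stated time of 60 min; a lower number here means a stronger inhibitor, a higher number a weaker inhibitor:
Compound 1, `CCC[C@H](c1ccc(C(=O)NCc2nn[nH]n2)cc1)N1C(=O)C(c2cc(Cl)cc(Cl)c2)=N[C@]12CC[C@@H](C(C)(C)C)CC2`, gives 55 nM.
Compound 2, `C[C@H](c1ccc(C(=O)NCCC(=O)O)cc1)N1C(=O)C(c2cccc(Cl)c2)=N[C@]12CC[C@@H](C(C)(C)C)CC2`, gives 130 nM.
Compound 3, `CC(C)(C)CC[C@H](c1ccc(C(=O)NCc2nn[nH]n2)cc1)N1C(=O)C(c2cc(Cl)cc(Cl)c2)=NC12CCCCC2`, gives 195 nM.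

Compound 1 carries the lowest of the three numbers; the nearest is compound 2, whose number lies beyond the scatter above it, and compound 3 lies further still. Compound 4, `CCCCC[C@H](c1ccc(C(=O)NCc2nn[nH]n2)cc1)N1C(=O)C(c2cc(Cl)cc(Cl)c2)=N[C@]12CC[C@@H](C(C)(C)C)CC2`, is the next member to be tested. Its change from compound 1 is ethyl in place of hydrogen on a saturated chain carbon, four bonds along the chain from an amide-type nitrogen in a ring and an aromatic carbon. Among the compounds with values here, no pair of measured compounds differs in exactly this way, so the size of the step is untested; compound 3 carries both a different chain and a different core, and its number cannot be read as the effect of the chain alone. In this assay only a small step is expected, in either direction, not clearly beyond the scatter. For compound 4 the expected value is 80 nM, range 30 nM to 250 nM, an expected step of a 1.5-fold higher number from compound 1 to compound 4 (0.16 log units; within the scatter).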

Compound 4, half-maximal inhibitory concentration: 24 nM
Compound 4: the middle estimate sits 3.3-fold (0.52 log units) above what was measured; measured number below the stated range.
By their numbers in this assay, from the lowest: compound 4; then compound 1; then compounds 2 and 3 (each within the scatter of the next).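

Lengthening the chain from propyl to pentyl, on the core of compound 1, gives a lower number in this assay (a 2.3-fold lower number from compound 1 to compound 4 (0.36 log units; beyond the scatter)). This saturated chain carbon, four bonds along the chain from an amide-type nitrogen in a ring and an aromatic carbon, therefore accepts ethyl in place of hydrogen without loss, and the step lies beyond the scatter. Nothing measured here accounts for the gain.

A single step does not establish how the number follows chain length. Going by these compounds, whether butyl, a longer chain such as hexyl, or a chain ending in an amine would give a lower number remains open.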